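The compounds below may be only part of what the source reports. "The series", "measured", "known", "first", "only" and "open" are said of these compounds alone.

Compound 1, with the structure `C=CCc1ccc(OCc2cn(-c3ccccc3Cl)nn2)c(O)c1`, was tested in a functional assay on SK-N-SH cells (Homo sapiens) for inhibition, read by MTT assay, with a stated time of 72 h, tested at 30 uM (a higher number here means more inhibition of growth at the concentration tested, a lower number less inhibition of growth), where compound 1 gives 10.2%. Among the measured compounds shown here, that is the lowest of the two numbers measured so far. For the measured compounds named here, the only other compound with a number, compound 2, has the structure `C=CCc1cc(O)c(O)c(CN2CCC(Cc3ccccc3)CC2)c1` and in this assay compound 2 gives 78.8%, a number that lies well beyond the usual scatter above the value of compound 1. The two compounds differ in many places at once, so their gap cannot be tied to any one structural change.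

Compound 3, with the structure `C=CCc1ccc(OCc2cn(-c3ccc(Br)cc3)nn2)c(O)c1`, has not yet been measured in this assay. It differs from compound 1 in one place: 4-bromophenyl in place of 2-chlorophenyl on an aromatic nitrogen. Going by the values given here, no pair of measured compounds shows what a change of this kind does here, so there is no measured step to lean on. With nothing in the data pointing either way, the step from compound 1 to compound 3 is expected to be small, a number 1.8 percentage points higher from compound 1 to compound 3 (within the scatter), within the scatter of repeated measurements. Compound 3 is therefore expected to give about 12% in this assay, in the range from 0% to 30%.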

Compound 3, percent growth inhibition at one concentration: 38.3%
Estimate against measurement, compound 3: 26.3 percentage points below; the whole stated range lies below it.
By their numbers in this assay, from the lowest: compound 1; then compound 3; then compound 2.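

Among the compounds shown here, the exchange of 2-chlorophenyl for 4-bromophenyl on an aromatic nitrogen of the five-membered aromatic ring is the first change in a single place with a reading in this assay, and it gives a number 28.1 percentage points higher from compound 1 to compound 3 (beyond the scatter). This shows that the position is not indifferent: the group carried on that nitrogen can shift growth inhibition at the tested concentration beyond the usual scatter, even though the two groups have the same count of heavy atoms, the same kind of ring, no hydrogen-bond donors or acceptors and no net charge. Nothing in the information at hand bears on what lies behind this step.

The compounds shown leave open whether the step follows the halogen or its place on the phenyl ring, as both change together here, and a 4-chlorophenyl or a 2-bromophenyl group on the same nitrogen would part the two. Also open, on these data alone, is what a plain phenyl, a 4-methoxyphenyl or a benzyl group would give at this position on the core of compound 1.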